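Opening a disulfide ring on a shared amide chain

The compounds below may be only part of what the source reports. "The series", "measured", "known", "first", "only" and "open" are said of these compounds alone.

Measured so far in a functional assay on HO8910 cells (Homo sapiens) for inhibition, read by MTT assay, with a stated time of 24 h, tested at 100 ug/mL; on this read-out higher numbers stand for more inhibition of growth at the one concentration tested and lower numbers for less inhibition of growth:
compound 1, `O=C(CCCCC1CCSS1)Nc1ccc([N+](=O)[O-])c(C(F)(F)F)c1`, gives 47.7%;
compound 2, `O=C(CCCCC1CCSS1)Nc1cccc2ccccc12`, is reported as "not active" (no number reported);
compound 3, `O=C(CCCCC(S)CCS)Nc1ccc([N+](=O)[O-])c(C(F)(F)F)c1`, gives 92.7%.

Compound 1 and compound 3 differ in one place: a group of 5 heavy atoms (3 carbon, 2 sulfur; no ring) in place of a group of 5 heavy atoms (3 carbon, 2 sulfur; one five-membered non-aromatic ring with 2 hetero atoms), on a saturated chain carbon, four bonds along the chain from a carbonyl carbon. This change gave a number 45 percentage points higher from compound 1 to compound 3 (beyond the scatter). The same change is now applied to compound 2 to give compound 4, `O=C(CCCCC(S)CCS)Nc1cccc2ccccc12`, which awaits testing in this assay: a group of 5 heavy atoms (3 carbon, 2 sulfur; no ring) in place of a group of 5 heavy atoms (3 carbon, 2 sulfur; one five-membered non-aromatic ring with 2 hetero atoms), on a saturated chain carbon, four bonds along the chain from a carbonyl carbon. The difference between the core of compound 1 and the core of compound 2 is not broken down here. For compound 2 no single number exists, only a report of no activity, so the step to compound 4 cannot be set beside the earlier one in size. If the change acts here as it did from compound 1 to compound 3, compound 4 is expected to reach about 40%, estimated between 10% and 75%.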

Compound 4, percent growth inhibition at one concentration: "not active" (no number reported)
For compound 4 the study gives words and no number; there is nothing to compare the estimate with.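

Compound 2 and compound 4 are both reported in this assay as not active, without numbers, so no step can be read between them. Nothing shown here accounts for this result. As far as these compounds go, whether opening the ring changes anything on the core of compound 2 remains open.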